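Working notes on the ring group of compound 2

This account rests on a few compounds, and the source may have more. Where it says the series, first, only, none or still open, it means among the compounds named here.

Measured so far in a physicochemical assay for solubility, read by HPLC, with a stated time of 24 h, at pH 7 (a higher number here means a more soluble compound, a lower number a less soluble compound), as follows
- compound 1 `O=C(O)c1cncc(CN2CCC[C@H](O[C@H](CO)c3cc(Cl)cc(Cl)c3)[C@@H]2c2ccccc2)c1` gives 74000 nM
- compound 2 `OC[C@@H](O[C@H]1CCCN(Cc2cccc3nonc23)[C@H]1c1ccccc1)c1cc(Cl)cc(Cl)c1` gives 154000 nM

Of these two numbers, the higher one in this assay belongs to compound 2 at 154000 nM and the lower one to compound 1 at 74000 nM in this series.

The next change leads to compound 3 `O=C(O)c1ccc2c(CN3CCC[C@H](O[C@H](CO)c4cc(Cl)cc(Cl)c4)[C@@H]3c3ccccc3)c[nH]c2c1` and is a group of 12 heavy atoms (9 carbon, 1 nitrogen, 2 oxygen; one five-membered aromatic ring with 1 hetero atom, one six-membered aromatic ring of carbon only) in place of a group of 9 heavy atoms (6 carbon, 2 nitrogen, 1 oxygen; one five-membered aromatic ring with 3 hetero atoms, one six-membered aromatic ring of carbon only), on a saturated chain carbon bound to an amine nitrogen in a ring with 6-carboxy-1H-indol-3-yl as the entering group. For the measured compounds named here, one measured step bears on it, namely a 2.1-fold higher number from compound 1 to compound 2 (0.32 log units; beyond the scatter) which is modest. That step installed the same group that now leaves. Compound 1 also holds a carboxy group, so compound 3 is expected to fall back towards compound 1 at 74000 nM rather than to hold the level of compound 2. Going by the values given here, no measured compound carries the indole group itself, so this reading is loose and the range stays wide.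

The expected step is a 2.2-fold lower number from compound 2 to compound 3 (0.34 log units; beyond the scatter) and it is a modest fall in the estimate. For compound 3 the estimated value is 70000 nM with an expected range from 20000 nM to 170000 nM in this assay when measured.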

Compound 3, solubility: 128000 nM
For compound 3 the middle estimate is 1.8-fold (0.26 log units) below the measured one, and the stated range covers the measured number.
By their numbers in this assay, from the lowest: compounds 1, 3 and 2 (each within the scatter of the next, the first and the last beyond it).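

In this assay, the position on a saturated chain carbon bound to an amine nitrogen in a ring accepts 6-carboxy-1H-indol-3-yl with a 1.2-fold lower number from compound 2 to compound 3 (0.08 log units; within the scatter), so this group cannot be told apart from the group of compound 2. For the compounds shown here, the exchange of 5-carboxypyridin-3-yl for 6-carboxy-1H-indol-3-yl gives a 1.7-fold higher number from compound 1 to compound 3 (0.24 log units; within the scatter) and likewise cannot be read as a change, which leaves compound 3 unresolved from both neighbours and means that the presence of a carboxy group does not sort these three compounds into two levels, although compound 1 and compound 2 remain separated by a 2.1-fold higher number from compound 1 to compound 2 (0.32 log units; beyond the scatter) as the only step beyond the scatter. No supporting measurement is available to explain these readings.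

The compounds shown leave open what the carboxylic acid contributes on the indole group, as no pair compares 6-carboxy-1H-indol-3-yl with plain 1H-indol-3-yl or with a primary amide or an aminomethyl group in the same place. They also leave open whether the flat profile holds for groups outside the fused and pyridine aromatic rings seen here, such as a saturated ring amine or a longer chain ending in a carboxylic acid.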